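Chain-linker variants of a peroxide series in liver microsomes

A few compounds are considered here, and "the series" means these few. Any claim that something is new, unique, unknown or untested is made for them only; others in the source may bear on it.

Compound 1 `NCCOCCOc1ccc([C@H]2CC[C@]3(CC2)OOC2(O3)C3CC4CC(C3)CC2C4)cc1` carries a 2-(2-aminoethoxy)ethoxy chain on the aryl ring of the shared core. In an ADME assay on microsomes from liver (Homo sapiens) for metabolic stability, read by LC-MS, tested at 1 uM (a lower number here means slower removal, a higher number faster removal of the compound), compound 1 gives < 7 mL.min-1.g-1, which is a limit of the assay rather than a number. Compound 2 `NCCCOc1ccc([C@H]2CC[C@]3(CC2)OOC2(O3)C3CC4CC(C3)CC2C4)cc1` is the nearest measured neighbour. In this assay compound 2 gives < 7 mL.min-1.g-1, again a limit of the assay. Within the data shown here, the one measured step, a step that the two limits leave unreadable from compound 1 to compound 2, is therefore unreadable in size. Compound 3 `NCCCCOc1ccc([C@H]2CC[C@]3(CC2)OOC2(O3)C3CC4CC(C3)CC2C4)cc1` differs from compound 1 by 2-aminoethyl in place of 2-aminoethoxy on a saturated chain carbon, two bonds along the chain from an oxygen on an aromatic ring. Among the measured compounds shown here, no measured step covers this exact change; the only bearing evidence is the limit of < 7 mL.min-1.g-1 in this assay, at which 2 of the 2 values shown sit, which shows both neighbours sitting at the same limit. With compound 1 at that limit, the step that the limit leaves unreadable from compound 1 to compound 3 is expected to be small or none beyond the scatter. Compound 3 is expected to give 5 mL.min-1.g-1 in this assay, within 2 mL.min-1.g-1 to 12 mL.min-1.g-1, most likely reported again as a limit.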

Compound 3, intrinsic clearance in microsomes: < 7 mL.min-1.g-1
Compound 3: a limit, no number; the forecaster's own chance of this, stated with the estimate: 70%; the middle value lies beyond the limit too.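

No step can be read among compound 1, compound 2 and compound 3 in this assay, since all three results are limits of the assay: the limit of < 7 mL.min-1.g-1 in this assay, at which 3 of the 3 values shown sit.

The compounds shown leave open whether these chains differ at all in intrinsic clearance in microsomes, and in what order.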